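The source may hold more compounds than are shown below. What is called first, only, known or untested is meant among the compounds shown, and "the series" means these compounds.

Measured so far in a functional assay on Bel-7402 cells (Homo sapiens) for cytotoxicity, read by MTT assay, with a stated time of 72 h; a lower number here means a stronger inhibitor, a higher number a weaker inhibitor:
- compound 1, `O=C(Nc1ccc(-n2ncc3c(C(F)(F)F)cccc32)cc1)Nc1ccc(Cl)c(C(F)(F)F)c1`, giving 16000 nM
- compound 2, `O=C(Nc1ccc(-n2ncc3c(Cl)cccc32)cc1)Nc1ccc(Cl)c(C(F)(F)F)c1`, giving 2500 nM

Compound 2 holds the lower of the two numbers. Among the measured compounds shown here, its only neighbour is compound 1, and the step of a 6.4-fold lower number from compound 1 to compound 2 (0.81 log units; beyond the scatter) separates them, a change of chloro in place of trifluoromethyl on an aromatic carbon of the shared core.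

Compound 3, `O=C(Nc1ccc(-n2ncc3c(Br)cccc32)cc1)Nc1ccc(Cl)c(C(F)(F)F)c1`, differs from compound 2 by bromo in place of chloro on an aromatic carbon. For the measured compounds named here, no measured pair shows this exchange: the single step on record, a 6.4-fold lower number from compound 1 to compound 2 (0.81 log units; beyond the scatter), concerns a different group at the same position, so it bears on compound 3 only by showing that this position is sensitive to what sits there. Going by the values given here, with no direct precedent, a change within the scatter, or a small one in either direction, is expected, which for the step from compound 2 to compound 3 means a 1.3-fold lower number from compound 2 to compound 3 (0.10 log units; within the scatter). Compound 3 is estimated at 2000 nM in this assay, with a range from 700 nM to 6000 nM.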

Compound 3, half-maximal inhibitory concentration: 1300 nM
Beside the measured number, compound 3's estimate is 1.5-fold (0.19 log units) above it, and the stated range covers the measured number.
By their numbers in this assay, from the lowest: compounds 3 and 2 (each within the scatter of the next); then compound 1.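

In this assay the exchange of chloro for bromo on this aromatic carbon gives a 1.9-fold lower number from compound 2 to compound 3 (0.28 log units; within the scatter) and so leaves the two halogens unseparated at this position. Bromo in place of trifluoromethyl gives a 12-fold lower number from compound 1 to compound 3 (1.09 log units; beyond the scatter) and thus a second halogen stands clear of compound 1 on the same carbon, which shows that the earlier gap was not peculiar to chloro. No measurement at hand explains why these groups read as they do.

The compounds shown do not tell how hydrogen, fluoro, an amine or a methoxy group would read on this carbon. Going by these compounds, whether the gap between trifluoromethyl and the halogens persists when the other end of the shared core carries different groups also stays open.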